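Swapping an Aryl Amide Group for an Open Chain

The compounds below may be only part of what the source reports. "The series", "measured", "known", "first", "only" and "open" are said of these compounds alone.

Values measured in a functional assay on Caco-2 cells (Homo sapiens) for antiproliferative activity, read by MTT assay, with a stated time of 48 h (a lower number here means a stronger inhibitor, a higher number a weaker inhibitor), follow
- compound 1 `CCn1c(C(=O)NCC#N)ccc1C(CC)(CC)c1ccc(OCCC(O)(CC)CC)c(C)c1` gives > 50000 nM (a limit)
- compound 2 `CCn1c(C(=O)Nc2ccc(OC(F)(F)F)cc2)ccc1C(CC)(CC)c1ccc(OCCC(O)(CC)CC)c(C)c1` gives > 50000 nM (a limit)

Compound 2 stands at a limit of the assay and not at a number, reading > 50000 nM in this assay with no exact strength known.

Compound 3 `CCC(C)C(NC(=O)c1ccc(C(CC)(CC)c2ccc(OCCC(O)(CC)CC)c(C)c2)n1CC)C(=O)O` differs from compound 2 by one change, 1-carboxy-2-methylbutyl in place of 4-(trifluoromethoxy)phenyl on an amide-type nitrogen. Counted out, the change reads 1-carboxy-2-methylbutyl in place of 4-(trifluoromethoxy)phenyl on an amide-type nitrogen and the entering group has no ring.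

Going by the values given here, the one measured step at this nitrogen is a step that the two limits leave unreadable from compound 1 to compound 2 with 4-(trifluoromethoxy)phenyl in place of cyanomethyl, so no clear gain in this assay is expected for compound 3. Among the compounds with values here, the evidence ends at the limit of > 50000 nM in this assay, at which 2 of the 2 values shown sit, and offers no measured number to step from. The expected step is a number no higher from compound 2 to compound 3 (the limit leaves the size open) and this estimate rests on limits alone. Compound 3 is estimated at 50000 nM with an expected range from 25000 nM to 100000 nM and most likely only a limit will be reported.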

Compound 3, half-maximal inhibitory concentration: 20000 nM
Compound 3: the middle estimate sits 2.5-fold (0.40 log units) above what was measured; the measured number lies below the stated range.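

In this assay, compound 3 is the only compound shown that gives a measured number and not a limit, so this amide-type nitrogen can carry a group that leaves a readable effect on the cells. Placing 1-carboxy-2-methylbutyl on this nitrogen gives an at least 2.5-fold lower number from compound 2 to compound 3 (0.39 log units; beyond the scatter) when it replaces the aryl group, and it gives an at least 2.5-fold lower number from compound 1 to compound 3 (0.39 log units; beyond the scatter) when it replaces cyanomethyl, so this open chain with its carboxylic acid improves on both earlier groups. The true size of these two steps could be larger, and the step between the two earlier groups cannot be read, because neither of those compounds has an exact number: the limit of > 50000 nM in this assay, at which 2 of the 3 values shown sit.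

On these data alone, whether the carboxylic acid or the branched carbon chain carries this gain stays open, and a methyl ester of that acid, or the same chain ending in an amine, would separate the two. Also open, as far as these compounds go, is whether a shorter or longer chain bearing the carboxylic acid would move the number further from that of compound 3 at 20000 nM in either direction.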